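The source may hold more compounds than are shown below. What is called first, only, known or untested is meant among the compounds shown, and "the series" means these compounds.

Measured so far in a functional assay on PC-3 cells (Homo sapiens) for inhibition, read by MTT assay; a higher number here means a weaker inhibitor, a lower number a stronger inhibitor:
- compound 1 `COc1c(N2CCN(C)CC2)c(F)cc2c(=O)c(C(=O)N/N=C\c3c(Cl)cccc3Cl)cn(C3CC3)c12`: 4.9 ug/mL
- compound 2 `COc1cc(/C=N\NC(=O)c2cn(C3CC3)c3c(OC)c(N4CCN(C)CC4)c(F)cc3c2=O)cc(OC)c1OC`: 8.5 ug/mL
- compound 3 `COc1c(N2CCN(C)CC2)c(F)cc2c(=O)c(C(=O)N/N=C\c3cccc(C)c3)cn(C3CC3)c12`: 10 ug/mL

The three share one core and differ only in the substituted phenyl group on the carbon with a double bond to nitrogen. In this assay, compound 3 gives 10 ug/mL. This cannot be told apart from the value of compound 2, as the step is small: a 1.2-fold higher number from compound 2 to compound 3 (0.07 log units; within the scatter). The gap to compound 1 is modest: a 2.0-fold higher number from compound 1 to compound 3 (0.31 log units; beyond the scatter).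

Next comes compound 4 `COc1cc(/C=N\NC(=O)c2cn(C3CC3)c3c(OC)c(N4CCN(C)CC4)c(F)cc3c2=O)ccc1O`, with the change 4-hydroxy-3-methoxyphenyl in place of 3-methylphenyl on a carbon with a double bond to nitrogen: 4-hydroxy-3-methoxyphenyl in place of 3-methylphenyl. The nearest measured precedent is the exchange of 3-methylphenyl and 3,4,5-trimethoxyphenyl, where compound 2 gave a 1.2-fold higher number from compound 2 to compound 3 (0.07 log units; within the scatter). The other exchange involving 3,4,5-trimethoxyphenyl, a 1.7-fold higher number from compound 1 to compound 2 (0.24 log units; within the scatter), also stays small, and the largest step seen at this place is only the modest one above. Among the measured compounds shown here, no measured compound carries a hydroxy group on this phenyl, so the range is kept wide.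

On this evidence, no step beyond the scatter is expected, and the expected change is a 1.3-fold lower number from compound 3 to compound 4 (0.10 log units; within the scatter). For compound 4 the estimated value is 8 ug/mL, with an expected range of 3.5 ug/mL to 18 ug/mL.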

Compound 4, half-maximal inhibitory concentration: 14.8 ug/mL
Beside the measured number, compound 4's estimate is 1.9-fold (0.27 log units) below it, within the range that was stated.
By their numbers in this assay, from the lowest: compounds 1, 2, 3 and 4 (each within the scatter of the next, the first and the last beyond it).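

Among the compounds shown here, this is the first phenyl at this place to carry a hydroxy group, and a hydrogen-bond donor enters with it, yet in this assay the result stays within the scatter of the 3-methylphenyl and 3,4,5-trimethoxyphenyl compounds (a 1.5-fold higher number from compound 3 to compound 4 (0.17 log units; within the scatter); a 1.7-fold higher number from compound 2 to compound 4 (0.24 log units; within the scatter)). Only the exchange with 2,6-dichlorophenyl clears the scatter (a 3.0-fold higher number from compound 1 to compound 4 (0.48 log units; beyond the scatter)), which is the largest step seen at this place and still a modest one, so compound 1 now stands beyond the scatter of both compound 3 and compound 4, while compound 2 stays within the scatter of compound 1 and of compound 4. No measurement at hand bears on why the steps fall as they do.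

The phenyl groups shown carry only chloro, methyl, methoxy and hydroxy substituents, so an amine or a carboxylic acid on the phenyl remains open, as does a saturated ring or a longer chain in its place. From the compounds shown here alone, whether the hydroxy group counts on its own also stays open, as compound 4 brings in a methoxy group with it.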